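The source may hold more compounds than are shown below. What is called first, only, known or untested is meant among the compounds shown, and "the series" means these compounds.

Measured compounds in a functional assay on the whole organism for inhibition, with Rattus norvegicus as the target, read by paw edema, with stated times of 30 min and 3 h, at a dose of 0.28 mmol/kg by the oral route; on this read-out lower numbers stand for less inhibition and higher numbers for more inhibition at the one dose given (going by the name of the read-out):
Compound 1, `CCNC(=O)c1nc(-c2cc(OC)c(OC)c(OC)c2)n(-c2ccc(OC)cc2)n1`: 101%
Compound 2, `COc1ccc(NC(=O)c2nc(-c3cc(OC)c(OC)c(OC)c3)n(-c3ccc(OC)cc3)n2)cc1`: 99%

Compound 2 stands lowest of these two numbers, but its nearest neighbour is compound 1, and the step of a number 2 percentage points lower from compound 1 to compound 2 (within the scatter) lies within the scatter, so the two values cannot be ordered. Compound 3, `COc1ccc(-n2nc(C(=O)Nc3ccccc3OC)nc2-c2cc(OC)c(OC)c(OC)c2)cc1`, has not yet been measured in this assay. It differs from compound 2 in one place: 2-methoxyphenyl in place of 4-methoxyphenyl on an amide-type nitrogen.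

Within the data shown here, the only measured step that touches the same position is the one from compound 1 to compound 2, where ethyl gave way to 4-methoxyphenyl on the amide-type nitrogen; that step was a number 2 percentage points lower from compound 1 to compound 2 (within the scatter), within the scatter. It shows the group on the amide-type nitrogen could be changed considerably without moving the read-out. Among the measured compounds shown here, no measured pair, however, exchanges 4-methoxyphenyl for 2-methoxyphenyl, so the present change rests on no direct precedent. On this basis no step beyond the scatter is expected, with the estimated step of a number 4 percentage points lower from compound 2 to compound 3 (within the scatter). Compound 3 is therefore expected to give about 95%, in the range 78% to 102%.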

Compound 3, a percentage reported as inhibition, in the whole organism at one dose (the size of the read-out at that dose, not a potency): 44%
Estimate against measurement, compound 3: 51 percentage points above, and the stated range ends above it.
By their numbers in this assay, from the lowest: compound 3; then compounds 2 and 1 (each within the scatter of the next).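

In this assay, the amide-type nitrogen proved less forgiving than the earlier pair had suggested. Putting 2-methoxyphenyl in place of 4-methoxyphenyl, two groups with the same heavy atoms and the same counts of donors and acceptors, gives a number 55 percentage points lower from compound 2 to compound 3 (beyond the scatter), and the replacement of ethyl gives a number 57 percentage points lower from compound 1 to compound 3 (beyond the scatter), although compound 1 and compound 2 lie within the scatter of each other; the read-out at this position therefore depends on how the atoms of the group are joined, not only on which atoms it holds. No measurement of any property bears on why the number falls at this position.

The compounds shown leave open whether the fall belongs to 2-methoxyphenyl alone or would also come with other groups, such as 2-methylphenyl, 2-chlorophenyl or 2-ethoxyphenyl, on the amide-type nitrogen. They also leave open where 3-methoxyphenyl or plain phenyl would stand on that nitrogen, and so whether 4-methoxyphenyl and ethyl are typical of this position or 2-methoxyphenyl is.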